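Series notes: amino in place of tert-butyl

The source may report more compounds than this note shows. Statements on the series, on what has been measured and on what is new or still open speak of the compounds shown alone.

Compound 1 `O=C(Nc1cccc(C(F)(F)F)c1)c1cc(=O)[nH]c2cc(Br)ccc12`: > 20000 nM
Compound 2 `O=C(Nc1cc(F)c(F)c(F)c1)c1cc(=O)[nH]c2cc(Br)ccc12`: > 20000 nM
Compound 3 `CC(C)(C)c1ccc(-c2ccc3c(C(=O)Nc4cccc(F)c4)cc(=O)[nH]c3c2)cc1`: > 20000 nM

In a functional assay on KYSE-70 cells for antiproliferative activity against KYSE-70 cell line (Homo sapiens), read by MTT assay, with a stated time of 72 h (on this read-out lower numbers stand for stronger inhibition and higher numbers for weaker inhibition), compound 1 gives > 20000 nM, which is a limit of the assay and not a number. Compound 2 likewise gives only a limit, > 20000 nM. Compound 3 also reaches only a limit, > 20000 nM. All three values sit at the limit of > 20000 nM in this assay, at which 3 of the 3 values shown sit, so compound 3 stands level with the others on what is shown, and no measured step exists in the series.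

Compound 4 `Nc1ccc(-c2ccc3c(C(=O)Nc4cccc(F)c4)cc(=O)[nH]c3c2)cc1` differs from compound 3 by amino in place of tert-butyl on an aromatic carbon. The expected step is a number no higher from compound 3 to compound 4 (the limit leaves the size open), that is none beyond the scatter, with a real chance that only a limit is reported again. Compound 4 is estimated at 20000 nM, expected to fall between 5000 nM and 60000 nM.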

Compound 4, half-maximal inhibitory concentration: > 20000 nM
Compound 4 was reported as a limit (the forecaster's own chance of this, stated with the estimate: 65%); the middle value sits exactly at the limit.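

Going by these compounds alone, compound 3 and compound 4 both stand only as limits, so no step between them can be read. The compounds shown leave open what, if anything, would bring a value off that limit: the limit of > 20000 nM in this assay, at which 4 of the 4 values shown sit.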